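Chloro in Place of Fluoro: Expected Effect on Cell Growth

A few compounds are considered here, and "the series" means these few. Any claim that something is new, unique, unknown or untested is made for them only; others in the source may bear on it.

Measured so far in a functional assay on MGC-803 cells (Homo sapiens) for antiproliferative activity, read by MTT assay; a lower number here means a stronger inhibitor, a higher number a weaker inhibitor:
- compound 1, `COc1ccccc1NC(=O)Nc1cccc(CNc2ncnc3ccccc23)c1`, gives 39300 nM
- compound 2, `O=C(Nc1cccc(CNc2ncnc3ccccc23)c1)Nc1ccccc1F`, gives 33400 nM

Compound 2 holds the lowest of the two numbers in this assay, but its nearest neighbour, compound 1, is separated from it only by a 1.2-fold lower number from compound 1 to compound 2 (0.07 log units; within the scatter), so the two cannot be told apart. Compound 3, `O=C(Nc1cccc(CNc2ncnc3ccccc23)c1)Nc1ccccc1Cl`, is the next member: chloro in place of fluoro on an aromatic carbon, which sits on an aromatic carbon of a six-membered aromatic ring of carbon only, ortho to a large group.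

For the measured compounds named here, the one step measured so far, from compound 1 to compound 2, concerns the same aromatic position, where fluoro replaced methoxy, and it stayed within the scatter. Going by the values given here, that is the only guide available, and it points to a small change at this position. On that basis the step from compound 2 to compound 3 in this assay is expected to be a 1.2-fold lower number from compound 2 to compound 3 (0.08 log units; within the scatter), not beyond the scatter in either direction. Compound 3 is therefore estimated at 28000 nM, within a range from 12000 nM to 70000 nM.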

Compound 3, half-maximal inhibitory concentration: > 50000 nM
Compound 3: only a limit was reported; the forecaster's own chance of this, stated with the estimate: 5%; middle value at least 1.7-fold (0.25 log units) away from the limit.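

In this assay compound 3 gives > 50000 nM, which is a limit of the assay and not a number. Chloro in place of fluoro on this aromatic carbon, ortho to a large group, gives an at least 1.4-fold higher number from compound 2 to compound 3 (0.17 log units; that floor lies within the scatter), and chloro in place of methoxy at the same carbon gives an at least 1.2-fold higher number from compound 1 to compound 3 (0.10 log units; that floor lies within the scatter), so each step has a floor but no measured size, and neither floor lies beyond the scatter. The earlier pair gave a fully measured step at this position, whereas with chloro the series reaches the end of the measurable range for the first time, which means that any comparison involving compound 3 has only one open-ended side: the limit of > 50000 nM in this assay, at which 1 of the 3 values shown sits.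

From the compounds shown here alone, whether the true value of compound 3 lies close to that limit or far past it remains open, and with it whether chloro truly differs from fluoro or methoxy at this position. The compounds shown also leave open how an amine, a carboxylic acid or a trifluoromethyl group on the same aromatic carbon would read in this assay.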